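From 4-fluorophenyl to thiophen-2-yl: an expected flat step

The source may hold more compounds than are shown below. What is called first, only, known or untested is meant among the compounds shown, and "the series" means these compounds.

Measured so far in a functional assay, read by spectrophotometry, tested at 100 uM; a lower number here means a stronger inhibitor, a higher number a weaker inhibitor:
Compound 1 `O=C(/C=C/c1ccccc1)c1cccc(NC(=O)c2cc(-c3ccncc3)n[nH]2)c1` gives 71500 nM
Compound 2 `O=C(/C=C/c1ccc(F)cc1)c1cccc(NC(=O)c2cc(-c3ccncc3)n[nH]2)c1` gives 58700 nM

Within the data shown here, only two numbers exist, and compound 2 stands level with compound 1 on them. The measured change is a 1.2-fold lower number from compound 1 to compound 2 (0.09 log units; within the scatter), so the two do not separate.

The next compound to be read is compound 3 `O=C(/C=C/c1cccs1)c1cccc(NC(=O)c2cc(-c3ccncc3)n[nH]2)c1`. Its difference from compound 2 is thiophen-2-yl in place of 4-fluorophenyl on a double-bonded chain carbon bound to a double-bonded chain carbon, which is thiophen-2-yl in place of 4-fluorophenyl on a double-bonded chain carbon bound to a double-bonded chain carbon.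

Among the measured compounds shown here, one measured step bears on this place, the fluoro in place of hydrogen on an aromatic carbon of the group that now leaves. That step, a 1.2-fold lower number from compound 1 to compound 2 (0.09 log units; within the scatter), stayed within the scatter. For the measured compounds named here, it is only a partial guide, since no measured compound has a different ring here.

With that single small step as the guide, no change beyond the scatter is expected in this assay, and the expected step is a 1.0-fold higher number from compound 2 to compound 3 (0.01 log units; within the scatter).

For compound 3 the estimated value is 60000 nM, with an expected range from 30000 nM to 110000 nM.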

Compound 3, half-maximal inhibitory concentration: 70000 nM
The estimate for compound 3 lay 1.2-fold (0.07 log units) below the measured number, within the range that was stated.
By their numbers in this assay, from the lowest: compounds 2, 3 and 1 (each within the scatter of the next).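

In this assay, replacing the whole ring on the double-bonded chain carbon, rather than a single substituent on it, still does not separate the compounds: thiophen-2-yl stands level with 4-fluorophenyl (a 1.2-fold higher number from compound 2 to compound 3 (0.08 log units; within the scatter)) and with phenyl (a 1.0-fold lower number from compound 1 to compound 3 (0.01 log units; within the scatter)). The earlier compounds shown here showed this only for a fluoro in place of a hydrogen, whereas these steps extend it to a five-membered aromatic ring with a hetero atom in place of a six-membered aromatic ring of carbon only. Nothing available accounts for why these exchanges leave the number within the scatter.

Going by these compounds, all three groups at this place are aromatic rings without a charge, so it remains open whether this position responds at all to a different kind of group, such as a cyclohexyl ring, or a phenyl ring carrying an amine or a carboxylic acid. The compounds shown also share the rest of their structure, so they cannot tell whether the same flat reading would hold on a changed core.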